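The source may hold more compounds than are shown below. What is called first, only, known or untested is meant among the compounds shown, and "the series" means these compounds.

Working notes on the series in an ADME assay on microsomes from liver (Mus musculus, strain CD1) for metabolic stability, read by LC-MS, with a stated time of 1 h; on this read-out lower numbers stand for a less stable compound and higher numbers for a more stable compound. Compound 1 `O=[N+]([O-])c1cn2c(n1)OC[C@@H](OCc1ccc(-c3ccc(CNc4ccccc4)cc3)cc1)C2` gives 52% in this assay. Compound 2 `O=[N+]([O-])c1cn2c(n1)OC[C@@H](OCc1ccc(-c3ccc(F)cc3)cc1)C2` gives 55% in this assay. Going by the values given here, the step of a number 3 percentage points higher from compound 1 to compound 2 (within the scatter) is the only measured step so far, so compound 2 stands alongside compound 1 with the two numbers indistinguishable within the scatter; there is no basis for ranking them.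

Compound 3 `O=[N+]([O-])c1cn2c(n1)OC[C@@H](OCc1ccc(-c3ccc(Oc4ccccc4)cc3)cc1)C2` is next in line and not yet measured in this assay. It differs from compound 2 by phenoxy in place of fluoro on an aromatic carbon. Among the compounds with values here, the only measured step that bears on this change is the one from compound 1 to compound 2, in which a large substituent at the same position was exchanged for fluoro, and that step was a number 3 percentage points higher from compound 1 to compound 2 (within the scatter). Within the data shown here, the move to compound 3 reverses the direction of that exchange in kind, putting a larger group back where fluoro sits, and on the single comparison available no step beyond the scatter is expected in this assay.

Compound 3 is therefore expected to give about 50% in this assay. The expected step is a number 5 percentage points lower from compound 2 to compound 3 (within the scatter). The expected range for compound 3 runs from 32% to 68%.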

Compound 3, percent of the compound remaining: 48%
For compound 3 the middle estimate is 2 percentage points above the measured one; the measured number falls inside the stated range.
By their numbers in this assay, from the lowest: compounds 3, 1 and 2 (each within the scatter of the next).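

In this assay, phenoxy in place of fluoro gives a number 7 percentage points lower from compound 2 to compound 3 (within the scatter), so a second large group on this aromatic carbon, para to a large group, now stands within the scatter of fluoro, and this time the group brings an aromatic ring of its own. Phenoxy in place of anilinomethyl gives a number 4 percentage points lower from compound 1 to compound 3 (within the scatter), so two large groups of different make-up also cannot be told apart here, and across compound 1, compound 2 and compound 3 no exchange at this place leaves the scatter, with none of the three going against that reading. No measurement on hand bears on why these numbers stay so close, or on which part of the molecules is affected during the incubation.

From the compounds shown here alone, whether any group at this place can move the read-out beyond the scatter remains open, for example a carboxylic acid, a primary amine or a longer alkyl chain. Also open, going by these compounds, is whether the same insensitivity would hold with the shared core changed, since all three compounds carry it unaltered.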